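The source may report more compounds than this note shows. Statements on the series, on what has been measured and on what is new or still open speak of the compounds shown alone.

Two compounds that share one core open this set. Compound 1 `CS(=O)(=O)c1ccc(Nc2ncc(F)c(Nc3nc4ccccc4s3)n2)cc1` carries a methylsulfonyl group on its outer ring, and compound 2 `NS(=O)(=O)c1ccc(Nc2ncc(F)c(Nc3nc4ccccc4s3)n2)cc1` carries a sulfamoyl group in the same place. In a functional assay on MCF7 cells (Homo sapiens) for antiproliferative activity, read by MTT assay, with a stated time of 48 h (a higher number here means a weaker inhibitor, a lower number a stronger inhibitor), compound 1 gives 6880 nM. Compound 2 reaches only a limit of this assay, > 50000 nM, not a number. Within the data shown here, the single change between them, (methyl in place of amino on a sulfonyl sulfur), therefore brings an at least 7.2-fold lower number from compound 2 to compound 1 (0.86 log units; beyond the scatter), and the step can be stated only as a lower bound because of the limit of > 50000 nM in this assay, at which 1 of the 3 values shown sits.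

Compound 3 `COc1ccc2nc(Nc3ccnc(Nc4ccc(S(N)(=O)=O)cc4)n3)sc2c1` sits on a different core, and its difference from compound 2 is not broken down here. It keeps the sulfamoyl group, and in this assay compound 3 gives 11000 nM.

Compound 4 `COc1ccc2nc(Nc3ccnc(Nc4ccc(S(C)(=O)=O)cc4)n3)sc2c1` is the methylsulfonyl partner of compound 3, made by the same change, (methyl in place of amino on a sulfonyl sulfur), on a sulfonyl sulfur with the same surroundings as before. Among the measured compounds shown here, only one measured example of this change exists, so the expectation rests on that single pair. If the change acts as it did in going from compound 2 to compound 1, compound 4 is expected to give a clearly lower number than compound 3, an estimated step of a 7.3-fold lower number from compound 3 to compound 4 (0.87 log units; beyond the scatter). Taken together, compound 4 is expected to land near 1500 nM, with a likely span from 500 nM to 5000 nM.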

Compound 4, half-maximal inhibitory concentration: > 50000 nM
Compound 4 gave a limit, no number (the forecaster's own chance of this, stated with the estimate: 5%); at least 33-fold (1.52 log units) between middle value and limit.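

In this assay, compound 4 reaches only a limit of the assay, > 50000 nM, and not a number. Replacing the amino group on the sulfonyl sulfur with methyl, which turns sulfamoyl into methylsulfonyl, therefore brings an at least 4.5-fold higher number from compound 3 to compound 4 (0.65 log units; beyond the scatter), so the change that helped on the first core hurts on the second, and its effect in this assay cannot simply be carried from one core to the other: the same change on two cores in this assay, an at least 7.2-fold lower number (0.86 log units; beyond the scatter) from compound 2 to compound 1 and an at least 4.5-fold higher number (0.65 log units; beyond the scatter) from compound 3 to compound 4, at least 33-fold (1.51 log units) apart, beyond the scatter of two such steps This does not show how large either step really is, or that one direction belongs to each core beyond these two pairs, and both steps remain lower bounds because of the assay's ceiling: the limit of > 50000 nM in this assay, at which 2 of the 4 values shown sit.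

The two cores differ in more than one place, including a fluoro group on one and a methoxy group on the other, so the compounds shown leave open which difference reverses the step. Also open, from the compounds shown here alone, is how another group on the sulfonyl sulfur, such as an ethyl chain or a dimethylamino group, would fare on either core.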